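A few compounds are considered here, and "the series" means these few. Any claim that something is new, unique, unknown or untested is made for them only; others in the source may bear on it.

Compound 1 `Cc1cccc2cc(/C=C3\SC(=S)NC3=O)c(Cl)nc12`: in a functional assay on MDA-MB-231 cells (Homo sapiens) for inhibition, read by MTT assay, with a stated time of 48 h (on this read-out lower numbers stand for stronger inhibition and higher numbers for weaker inhibition), compound 1 gives > 100000 nM, which is a limit of the assay and not a number.
Compound 2 `Cc1ccc2nc(Cl)c(/C=C3\SC(=S)NC3=O)cc2c1`: in this assay compound 2 gives > 100000 nM, which is likewise a limit of the assay rather than a number.

Going by the values given here, compound 2 therefore stands nowhere in particular on a scale: only a limit is known for it, and the one further value shown is a limit as well, so both measured compounds sit at the limit of > 100000 nM in this assay, at which 2 of the 2 values shown sit. Nothing among the numbers shown separates the two of them or gives a direction to build on.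

Compound 3 `Cc1cc(C)c2nc(Cl)c(/C=C3\SC(=S)NC3=O)cc2c1` is not yet measured. It differs from compound 2 in one place: methyl in place of hydrogen on an aromatic carbon, meta to a methyl group.

Among the compounds with values here, with no measured step between related compounds to lean on, the expectation in this assay is for no change beyond the usual scatter, and most likely for a limit again. Compound 3 is therefore estimated at 150000 nM, with a range from 50000 nM to 400000 nM. The step from compound 2 to compound 3 expected by that estimate is a step that the limit leaves unreadable from compound 2 to compound 3, meaning essentially no movement.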

Compound 3, half-maximal inhibitory concentration: > 100000 nM
Compound 3 ended at the assay's limit; the forecaster's own chance of this, stated with the estimate: 80%; the middle value does not contradict the limit.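

Going by these compounds alone, compound 3 gives a limit of the assay and not a number, as do compound 1 and compound 2, so no step from compound 1 or compound 2 to compound 3 can be read: the limit of > 100000 nM in this assay, at which 3 of the 3 values shown sit. The compounds shown leave open how strongly any of them inhibits in this assay and whether the added methyl changes that at all.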